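The source may hold more compounds than are shown below. What is called first, only, known or untested is meant among the compounds shown, and "the series" means these compounds.

Series notes. Compound 3 `CC(C)N1CCc2nc(C#Cc3ccc(Cl)cc3)ccc2C1=O` gives 27100 nM in an assay on HEK293 cells for displacement of a labelled ligand from metabotropic glutamate receptor 5 (Homo sapiens), with a stated time of 2 h; on this read-out higher numbers stand for weaker inhibition and lower numbers for stronger inhibition; this is the second highest of three numbers, with compound 1 `CN1CCc2nc(C#Cc3cccnc3)ccc2C1=O` at 27400 nM within the scatter of it, and compound 2 `CC(C)N1CCc2nc(C#Cc3ccccc3Cl)ccc2C1=O` at 5680 nM as the furthest. Within the data shown here, the single measured step, a 4.8-fold higher number from compound 2 to compound 3 (0.68 log units; beyond the scatter), concerns only the chlorophenyl exchange. Compound 4 `CC(C)N1CCc2nc(C#Cc3cccnc3)ccc2C1=O` differs from compound 3 by pyridin-3-yl in place of 4-chlorophenyl on a triple-bonded carbon. Among the measured compounds shown here, no measured step covers this exchange; the only guide is compound 1, which also carries pyridin-3-yl and gives 27400 nM, a value matching that of compound 3 within the scatter. The expected step is therefore a 1.1-fold lower number from compound 3 to compound 4 (0.04 log units; within the scatter), none beyond the scatter. Compound 4 is estimated at 25000 nM, range 8000 nM to 80000 nM.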

Compound 4, inhibition constant: 19600 nM
Compound 4: the middle estimate sits 1.3-fold (0.11 log units) above what was measured, and the stated range covers the measured number.
By their numbers in this assay, from the lowest: compound 2; then compounds 4, 3 and 1 (each within the scatter of the next).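

Pyridin-3-yl on a triple-bonded carbon sits level with 4-chlorophenyl (a 1.4-fold lower number from compound 3 to compound 4 (0.14 log units; within the scatter)), while the change from 2-chlorophenyl is larger (a 3.5-fold higher number from compound 2 to compound 4 (0.54 log units; beyond the scatter)), so among the isopropyl compounds only compound 2 stands apart. With pyridin-3-yl held, isopropyl in place of methyl on an amide-type nitrogen in a ring stays within the scatter (a 1.4-fold lower number from compound 1 to compound 4 (0.15 log units; within the scatter)). No evidence at hand bears on these results.

Still open, as far as these compounds go, is how a methoxy group or a nitrile in place of the chlorine on the phenyl ring would read. From the compounds shown here alone, a longer chain on the amide-type nitrogen also remains open.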